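Thiophen-2-yl in Place of 4-Methylphenyl: Compound 3

A few compounds are considered here, and "the series" means these few. Any claim that something is new, unique, unknown or untested is made for them only; others in the source may bear on it.

Of the compounds shown here, two have been measured. Compound 1 `CC(C)(C)Cc1c(-c2ccncc2)sc(N)c1C(=O)c1ccc(Cl)cc1` gives in an assay on CHO cells for displacement of a labelled ligand from adenosine receptor A1 (Homo sapiens), read by scintillation counting, tested at 10 uM (a higher number here means more inhibition at the concentration tested (going by the name of the read-out), a lower number less inhibition), a read-out of 1%. Compound 2 `Cc1ccc(-c2sc(N)c(C(=O)c3ccc(Cl)cc3)c2CC(C)(C)C)cc1` gives in this assay a read-out of 1%. The step between them, no change at the digits printed from compound 1 to compound 2 (within the scatter), is a swap of one aromatic ring for another on the same aromatic carbon, and it left the read-out where it was. Compound 2 therefore stands level with compound 1 at the digits shown, and neither shows any inhibition worth noting at the concentration tested.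

Compound 3 `CC(C)(C)Cc1c(-c2cccs2)sc(N)c1C(=O)c1ccc(Cl)cc1` is the next compound and differs from compound 2 in one place: thiophen-2-yl in place of 4-methylphenyl on an aromatic carbon. Within the data shown here, the only measured step that bears on this change is the one from compound 1 to compound 2, where a different ring at this very carbon made no difference within the scatter. Among the measured compounds shown here, with only that step to draw on, no shift beyond the scatter is expected in this assay for compound 3, and the expected step of a number 2 percentage points higher from compound 2 to compound 3 (within the scatter) is essentially nothing. The estimate for compound 3 is 3%, with a range from -7% to 13%.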

Compound 3, a percentage reported as inhibition, at one concentration (the size of the read-out at that concentration, not a potency): 1%
The estimate for compound 3 lay 2 percentage points above the measured number; the measured number falls inside the stated range.
By their numbers in this assay, from the lowest: compounds 1, 2 and 3 (each within the scatter of the next).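

In this assay thiophen-2-yl in place of 4-methylphenyl gives no change at the digits printed from compound 2 to compound 3 (within the scatter) and thiophen-2-yl in place of pyridin-4-yl gives no change at the digits printed from compound 1 to compound 3 (within the scatter) at this same aromatic carbon on the shared core. The earlier compounds shown here had only six-membered aromatic rings here, so these steps extend the flat result to a five-membered aromatic ring with a sulfur, and the read-out stays level across all three rings despite their different heavy-atom counts and hydrogen-bond acceptor counts. Nothing available explains why the read-out stays level across these rings.

All three compounds share the neopentyl group, the amino group and the (4-chlorophenyl)carbonyl group, so these compounds cannot tell whether any of those three groups has a bearing on the read-out. From the compounds shown here alone, it also remains open whether a non-aromatic group at the carbon next to the ring sulfur, such as a primary amine, a carboxylic acid or a longer alkyl chain, would give a read-out any different from that of the three aromatic rings.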